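Triazole thioacetanilide oximes: removing one methoxy group

The source may report more compounds than this note shows. Statements on the series, on what has been measured and on what is new or still open speak of the compounds shown alone.

Measured compounds in a functional assay on the whole organism (strain albino) for inhibition, with Rattus norvegicus as the target, read by paw edema, with stated times of 30 min and 3 h, at a dose of 0.28 mmol/kg by the oral route; on this read-out higher numbers stand for more inhibition at the one dose given (going by the name of the read-out) and lower numbers for less inhibition:
compound 1 `C=CCn1c(SCC(=O)Nc2ccc(/C(C)=N/O)cc2)nnc1-c1ccccc1` — 73%
compound 2 `COc1ccc(-c2nnc(SCC(=O)Nc3ccc(/C(C)=N/O)cc3)n2-c2ccccc2)cc1` — 57%
compound 3 `C=CCn1c(SCC(=O)Nc2ccc(/C(C)=N/O)cc2)nnc1-c1ccc(OC)c(OC)c1` — 70%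

On the numbers shown compound 3 sits second of three: compound 1 lies within the scatter of it, compound 2 lies beyond the scatter, lower. Within the data shown here, the only single-point step measured is a number 3 percentage points lower from compound 1 to compound 3 (within the scatter), which shows that adding two methoxy groups to the phenyl on the aromatic carbon leaves the read-out essentially unchanged.

Compound 4 `C=CCn1c(SCC(=O)Nc2ccc(/C(C)=N/O)cc2)nnc1-c1ccc(OC)cc1` is the next step from compound 3: hydrogen in place of methoxy on an aromatic carbon. Compound 4 thus stands halfway, in structure, between compound 1 and compound 3, whose values lie within the scatter of each other. Among the measured compounds shown here, no measured step speaks against a flat outcome; compound 2 carries a different group on the triazole nitrogen as well, so its lower value cannot be attributed to the methoxy count alone.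

The expected step is therefore a number 1 percentage points higher from compound 3 to compound 4 (within the scatter), none beyond the scatter. In this assay compound 4 is estimated at 71%, with a range from 58% to 82%.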

Compound 4, a percentage reported as inhibition, in the whole organism at one dose (the size of the read-out at that dose, not a potency): 63%
For compound 4 the middle estimate is 8 percentage points above the measured one; the measured number falls inside the stated range.
By their numbers in this assay, from the lowest: compounds 2, 4, 3 and 1 (each within the scatter of the next, the first and the last beyond it).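

In this assay, the methoxy ortho to a methoxy group and meta to a large group can be removed with a number 7 percentage points lower from compound 3 to compound 4 (within the scatter), so this single change stays within the scatter, and a number 10 percentage points lower from compound 1 to compound 4 (within the scatter) shows the same for 4-methoxyphenyl against plain phenyl. Among these compounds, compound 4 also gives the first single-place reading on the aromatic nitrogen, a number 6 percentage points higher from compound 2 to compound 4 (within the scatter), which links compound 2 to the allyl compounds through one change, although compound 2 and compound 1 themselves differ in two places. No measurement on hand accounts for these steps.

Open, going by these compounds, is what an amine or a carboxylic acid would give in place of this methoxy on the ring. Also open, on these data alone, is whether a longer chain than allyl on the aromatic nitrogen would move the read-out beyond the scatter.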